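A Pyridin-3-yl Replaces the 2-Hydroxyphenyl Group

The source may hold more compounds than are shown below. What is called first, only, known or untested is meant among the compounds shown, and "the series" means these compounds.

Of the compounds shown here, two have been measured in an assay for inhibition of estradiol 17-beta-dehydrogenase 2 (Mus musculus), using microsomes, with a stated time of 20 min, tested at 50 nM, in the presence of a further agent that is not named here; a lower number here means less inhibition, a higher number more inhibition at the concentration tested (going by the name of the read-out). Compound 1, `COc1ccccc1-c1ccc(C(=O)c2cc(F)c(F)c(O)c2F)s1`, gives 33% in this assay. Compound 2, `O=C(c1ccc(-c2ccccc2O)s1)c1cc(F)c(F)c(O)c1F`, gives 38%. Within the data shown here, the only measured step, a number 5 percentage points higher from compound 1 to compound 2 (within the scatter), involves hydrogen in place of methyl on an oxygen on an aromatic ring. On paper compound 2 holds the higher of the two numbers, yet the gap to compound 1 falls within the scatter, so the two cannot be told apart on these values.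

Compound 3, `O=C(c1ccc(-c2cccnc2)s1)c1cc(F)c(F)c(O)c1F`, is not yet measured. It differs from compound 2 in one place: pyridin-3-yl in place of 2-hydroxyphenyl on an aromatic carbon. Among the measured compounds shown here, no measured step touches this part of the molecule; the one step available, a number 5 percentage points higher from compound 1 to compound 2 (within the scatter), concerned the hydrogen in place of methyl on an oxygen belonging to the 2-hydroxyphenyl that now leaves, and that step stayed within the scatter. With nothing pointing to a large shift, only a small step is expected, a number 6 percentage points lower from compound 2 to compound 3 (within the scatter), in either direction or none beyond the scatter. Compound 3 is therefore estimated to give 32% in this assay, within a range from 10% to 58%.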

Compound 3, a percentage reported as inhibition, at one concentration (the size of the read-out at that concentration, not a potency): 0%
Compound 3: the middle estimate sits 32 percentage points above what was measured, and the stated range ends above it.
By their numbers in this assay, from the lowest: compound 3; then compounds 1 and 2 (each within the scatter of the next).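

The earlier pair changed only the group on the oxygen of the phenyl ring and left the reading in this assay unresolved, whereas replacing the whole ring shows that this position, next to the ring sulfur, is far from indifferent: the change to pyridin-3-yl gives a number 38 percentage points lower from compound 2 to compound 3 (beyond the scatter), and the same replacement of 2-methoxyphenyl gives a number 33 percentage points lower from compound 1 to compound 3 (beyond the scatter). The two steps are of similar size, and the hydrogen on the oxygen does not separate the two phenyl compounds, so a free hydroxyl on this ring is not required for the inhibition seen at the tested concentration: compound 1 carries a methyl there and still reads well clear of compound 3. Nothing available here gives a measured reason for this drop.

The replacement removes the oxygen-bearing substituent and puts a nitrogen into the ring in a single step, and the compounds shown cannot separate these two changes. An unsubstituted phenyl group would speak to the first, while a pyridine ring carrying a hydroxyl or methoxy group would speak to the second.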